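Swapping a Fluorophenyl for Thiophene on a Shared Core

The source may report more compounds than this note shows. Statements on the series, on what has been measured and on what is new or still open speak of the compounds shown alone.

Three measured compounds share one core and differ only in the aryl group attached to it. Compound 1 `Clc1ccc(-c2cn3ccnc3c(-c3ccc4ncn(C5CCCCC5)c4c3)n2)cc1` gives 3.78% in a functional assay on OVCAR-8 cells (Homo sapiens) for inhibition, read by sulforhodamine B assay, with a stated time of 48 h, tested at 10 uM; a higher number here means more inhibition at the concentration tested (going by the name of the read-out), a lower number less inhibition. Compound 2 `COc1ccccc1-c1cn2ccnc2c(-c2ccc3ncn(C4CCCCC4)c3c2)n1` gives 8.78%, and compound 3 `Fc1ccccc1-c1cn2ccnc2c(-c2ccc3ncn(C4CCCCC4)c3c2)n1` gives 14.1%, the highest of the three numbers, though only its gap to compound 1 is beyond the scatter: a number 10.3 percentage points higher from compound 1 to compound 3 (beyond the scatter), while a number 5 percentage points higher from compound 1 to compound 2 (within the scatter) and a number 5.3 percentage points higher from compound 2 to compound 3 (within the scatter). Compound 4 `c1csc(-c2cn3ccnc3c(-c3ccc4ncn(C5CCCCC5)c4c3)n2)c1` alters compound 3 by thiophen-2-yl in place of 2-fluorophenyl on an aromatic carbon. For the measured compounds named here, no measured step replaces a six-membered ring with a five-membered one, so none bears directly on this change; every measured step moved the read-out only modestly within a low band. The step is therefore expected to be a number 4.1 percentage points lower from compound 3 to compound 4 (within the scatter), no larger than the scatter. Compound 4 is expected to give about 10%, between 0% and 25%.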

Compound 4, a percentage reported as inhibition, at one concentration (the size of the read-out at that concentration, not a potency): 9.34%
Beside the measured number, compound 4's estimate is 0.7 percentage points above it; the range from low to high includes it.
By their numbers in this assay, from the lowest: compounds 1, 2, 4 and 3 (each within the scatter of the next, the first and the last beyond it).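

Measured by this assay the change to thiophen-2-yl gives a number 4.8 percentage points lower from compound 3 to compound 4 (within the scatter) as well as a number 0.6 percentage points higher from compound 2 to compound 4 (within the scatter) and a number 5.6 percentage points higher from compound 1 to compound 4 (within the scatter) at this aromatic carbon. A five-membered aromatic ring with 1 hetero atom therefore stands here without separating, beyond the scatter, from any of the three six-membered aryl groups. No available information explains this result.

Going by these compounds, whether an amine, a carboxylic acid or a longer chain on this carbon would give a clearly higher number remains open.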